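The compounds below may be only part of what the source reports. "The series", "measured", "known", "first", "only" and "open" are said of these compounds alone.

Compound 1 `Cc1noc(C)c1S(=O)(=O)N1CCC(N2CCC(C)CC2)CC1`: in an ADME assay on HCT-116 cells (Homo sapiens) for cytotoxicity, read by CellTiter-Glo, with a stated time of 72 h (a higher number here means a weaker inhibitor, a lower number a stronger inhibitor), compound 1 gives > 10000 nM, which is a limit of the assay and not a number.
Compound 2 `CC1CCN(C2CCN(S(=O)(=O)c3sc(Cl)nc3C3CC3)CC2)CC1`: in this assay compound 2 gives > 10000 nM, again a limit.
Compound 3 `Cc1nc(Cl)sc1S(=O)(=O)N1CCC(N2CCC(C)CC2)CC1`: in this assay compound 3 gives > 10000 nM, also a limit.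

Compound 3 thus stands only at a limit, as do the other two values shown (the limit of > 10000 nM in this assay, at which 3 of the 3 values shown sit). The steps a step that the two limits leave unreadable from compound 1 to compound 3 and a step that the two limits leave unreadable from compound 2 to compound 3 each swap one group, on a sulfonyl sulfur or on an aromatic carbon, yet neither can be read in size. Compound 4 `CC1CCN(C2CCN(S(=O)(=O)c3nccn3C)CC2)CC1` carries the change (1-methyl-1H-imidazol-2-yl in place of 2-chloro-4-methyl-1,3-thiazol-5-yl on a sulfonyl sulfur). With no readable step to lean on, a step that the limit leaves unreadable from compound 3 to compound 4 is estimated, and compound 4 is expected to give 15000 nM, between 5000 nM and 50000 nM.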

Compound 4, half-maximal inhibitory concentration: > 10000 nM
Compound 4: no number, only a limit (the forecaster's own chance of this, stated with the estimate: 80%); the middle value does not contradict the limit.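

Compound 4 also gives only a limit, so the size of its steps from compound 3 and compound 1 cannot be read: the limit of > 10000 nM in this assay, at which 4 of the 4 values shown sit. The compounds shown leave open whether changing the group on the sulfonyl sulfur alters the result in this assay.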